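The compounds below may be only part of what the source reports. "The series", "measured", "known", "first", "only" and "open" are said of these compounds alone.

Compound 1 `NCc1cccc(CN(Cc2nc3ccccc3[nH]2)C2CCCc3cccnc32)c1`, compound 2 `NC/C=C\CN(Cc1nc2ccccc2[nH]1)C1CCCc2cccnc21` and compound 3 `NC/C=C/CN(Cc1nc2ccccc2[nH]1)C1CCCc2cccnc21` share one core and differ only in the group on a saturated chain carbon bound to an amine nitrogen. In a functional assay on CEM-CCRF cells for antagonist activity at C-X-C chemokine receptor type 4 (Homo sapiens), read by calcium flux (on this read-out higher numbers stand for weaker inhibition and lower numbers for stronger inhibition), compound 1 gives 1400 nM, compound 2 gives 77 nM and compound 3 gives 160 nM, so compound 3 stands second highest of the three, nearest to compound 2 and furthest from compound 1. Replacing 3-(aminomethyl)phenyl with 3-aminoprop-1-en-1-yl brought an 18-fold lower number from compound 1 to compound 2 (1.26 log units; beyond the scatter) and an 8.8-fold lower number from compound 1 to compound 3 (0.94 log units; beyond the scatter), while the drawn double-bond geometry alone gave a 2.1-fold higher number from compound 2 to compound 3 (0.32 log units; beyond the scatter), a difference resting on (the fact that one of compounds 2 and 3 is drawn with a defined configuration and the other without, at the place where they differ). Compound 4 `NCC#CCN(Cc1nc2ccccc2[nH]1)C1CCCc2cccnc21` carries the change (3-aminoprop-1-yn-1-yl in place of 3-aminoprop-1-en-1-yl on a saturated chain carbon bound to an amine nitrogen). Among the compounds with values here, no measured step exchanges a double bond for a triple bond; the closest comparison, the geometry change, was modest, so a step of a 1.3-fold higher number from compound 3 to compound 4 (0.10 log units; within the scatter) is expected, near the scatter. Compound 4 is therefore estimated at 200 nM in this assay, ranging from 60 nM to 700 nM.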

Compound 4, half-maximal inhibitory concentration: 973 nM
For compound 4 the middle estimate is 4.9-fold (0.69 log units) below the measured one; the measured number lies above the stated range.
By their numbers in this assay, from the lowest: compound 2; then compound 3; then compounds 4 and 1 (each within the scatter of the next).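

Among these chains, the exact type of carbon-carbon bond matters: the triple bond gives a 6.1-fold higher number from compound 3 to compound 4 (0.78 log units; beyond the scatter) and a 13-fold higher number from compound 2 to compound 4 (1.10 log units; beyond the scatter), a larger change than the double-bond geometry produced. The gain from leaving 3-(aminomethyl)phenyl for the double-bond chain does not carry over to the triple-bond chain, with a 1.4-fold lower number from compound 1 to compound 4 (0.16 log units; within the scatter). Nothing available explains the weaker inhibition of compound 4.

Still open, on these data alone, is whether a saturated 3-aminopropyl chain, or a longer chain ending in the same amine, would behave like the double-bond compounds or like compound 4.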